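Arylpiperazine amide series: electroshock read-outs and a new analogue

A few compounds are considered here, and "the series" means these few. Any claim that something is new, unique, unknown or untested is made for them only; others in the source may bear on it.

Compound 1 `CC(C(=O)N1CCN(c2ccccc2)CC1)N1C(=O)CCC1=O`, compound 2 `CCC(C(=O)N1CCN(c2ccccc2Cl)CC1)N1C(=O)CCC1=O` and compound 3 `CC(C(=O)N1CCN(c2ccc(C(F)(F)F)cc2)CC1)N1C(=O)CCC1=O` share one core and differ only in the aryl group on the ring nitrogen and in the side chain. In a functional assay on the whole organism (strain Swiss) with Mus musculus as the target, in the maximal electroshock model, with a stated time of 2 h, at a dose of 300 mg/kg by the intraperitoneal route (a lower number here means a weaker effect, a higher number a stronger effect of the compound at the dose given), compound 1 gives 0%. For the measured compounds named here, in the same assay compound 3 gives 0%, so the single one-place step measured so far, no change at the digits printed from compound 1 to compound 3 (within the scatter), is flat. Compound 2 gives 0% in this assay, level with compound 1 and compound 3 at the digits shown; no step to either is computed, and the three values show nothing more than a common level.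

Compound 4 `CCC(C(=O)N1CCN(c2ccc(F)cc2)CC1)N1C(=O)CCC1=O` has not yet been measured. Relative to compound 2 the change is 4-fluorophenyl in place of 2-chlorophenyl on an amine nitrogen in a ring. Going by the values given here, no measured step concerns the halogen on this aryl group. Among the compounds with values here, the only step available, no change at the digits printed from compound 1 to compound 3 (within the scatter), alters a substituent on the same aryl ring and stays within the scatter, and compound 2 with its chlorine-bearing aryl sits at the same floor as compound 1 and compound 3. Expected, therefore, is no change at the digits printed from compound 2 to compound 4 (within the scatter), no shift beyond the scatter. For compound 4 the estimate in this assay is 0%, within 0% to 15%.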

Compound 4, a percentage reported as activity, at one dose (the size of the read-out at that dose, not a potency): 0%
The estimate for compound 4 equals the measured number at the digits printed; the measured number falls inside the stated range.
By their numbers in this assay, from the lowest: compounds 1, 2, 3 and 4 (each within the scatter of the next).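

In this assay, exchanging 2-chlorophenyl for 4-fluorophenyl on an amine nitrogen in a ring gives no change at the digits printed from compound 2 to compound 4 (within the scatter). For the compounds shown here, this is the first measured step that changes the halogen-bearing aryl group while the side chain of compound 2 stays in place, and it extends the flat result seen so far with trifluoromethyl in place of hydrogen to an exchange of one halogen-bearing aryl group for another. No supporting data bear on why this exchange leaves the read-out flat.

The step changes the halogen and its ring position together, so the contribution of each remains unresolved, and the common level of all four compounds in this assay gives no order among these aryl groups. Also open, going by these compounds, is whether a hydroxyl or methoxy group on the aryl ring, an amine or carboxylic acid on the same ring, or a longer chain in place of the present side chain would move the read-out away from this level.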